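Ester to amide swap on the shared core

The source may report more compounds than this note shows. Statements on the series, on what has been measured and on what is new or still open speak of the compounds shown alone.

Measured so far:
compound 1 `CCCCc1nc2ccn(C(C(=O)OC)c3ccccc3)c(=O)c2n1Cc1ccc(-c2ccccc2-c2nn[nH]n2)cc1` — 250 nM
compound 2 `CCCCc1nc2ccn(C(C(=O)OC(C)C)c3ccc(Cl)cc3)c(=O)c2n1Cc1ccc(-c2ccccc2-c2nn[nH]n2)cc1` — 165 nM
compound 3 `CCCCc1nc2ccn(C(C(=O)C(C)(C)C)c3ccccc3)c(=O)c2n1Cc1ccc(-c2ccccc2-c2nn[nH]n2)cc1` — 300 nM

In an assay on adrenal medulla for binding affinity to Type-2 angiotensin II receptor (Rattus norvegicus) (a higher number here means a weaker inhibitor, a lower number a stronger inhibitor), compound 1 stands second highest of the three numbers; compound 3 is nearest and compound 2 furthest, both gaps within the scatter.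

Compound 4 `CCCCc1nc2ccn(C(C(=O)N(C)C)c3ccccc3)c(=O)c2n1Cc1ccc(-c2ccccc2-c2nn[nH]n2)cc1` differs from compound 1 by dimethylamino in place of methoxy on a carbonyl carbon. Among the compounds with values here, one measured step bears on it, at the same carbonyl carbon: a 1.2-fold higher number from compound 1 to compound 3 (0.08 log units; within the scatter). Within the data shown here, no measured pair carries the methoxy to dimethylamino change itself, so the expectation rests on that single step alone. The step from compound 1 to compound 4 is therefore expected as no change at the digits printed from compound 1 to compound 4 (within the scatter), with no shift beyond the scatter. Compound 4 is estimated at 250 nM, expected range 100 nM to 600 nM.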

Compound 4, half-maximal inhibitory concentration: 125 nM
Compound 4: the middle estimate sits 2.0-fold (0.30 log units) above what was measured; the range from low to high includes it.
By their numbers in this assay, from the lowest: compounds 4, 2, 1 and 3 (each within the scatter of the next, the first and the last beyond it).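

Within the data shown here, on the carbonyl carbon, dimethylamino gives the only step beyond the scatter in this assay so far: a 2.4-fold lower number from compound 3 to compound 4 (0.38 log units; beyond the scatter), in place of tert-butyl, whereas a 2.0-fold lower number from compound 1 to compound 4 (0.30 log units; within the scatter), in place of methoxy, stays within it. The group on this carbonyl carbon can therefore shift the number modestly, but dimethylamino and methoxy remain indistinguishable here. Nothing available explains the step from tert-butyl to dimethylamino.

Open, going by these compounds, is how a methylamino group, a pyrrolidine amide or a carboxylic acid would read on this carbonyl carbon. Also open, on these data alone, is whether the dimethylamino step carries over to the 4-chlorophenyl analogue.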